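This account rests on a few compounds, and the source may have more. Where it says the series, first, only, none or still open, it means among the compounds named here.

Compound 1 `O=C(Nc1cccc(-n2cc(-c3ccncc3)c(-c3ccc(Cl)c(O)c3)n2)c1)Nc1cccc(C(F)(F)F)c1`: 3650 nM
Compound 2 `COc1cc(-c2nn(-c3cccc(NC(=O)Nc4ccc(Cl)c(Cl)c4)c3)cc2-c2ccncc2)ccc1Cl`: 1050 nM
Compound 3 `O=C(Nc1cccc(-n2cc(-c3ccncc3)c(-c3ccc(Cl)c(O)c3)n2)c1)Nc1ccc(Cl)c(Cl)c1`: 1090 nM

These numbers come from a functional assay on SNB-75 cells (Homo sapiens) for inhibition, read by sulforhodamine B assay, with a stated time of 48 h; on this read-out higher numbers stand for weaker inhibition of growth and lower numbers for stronger inhibition of growth. Compound 2 stands at the low end of the three, level with compound 3, and the two are separated only by a 1.0-fold higher number from compound 2 to compound 3 (0.02 log units; within the scatter). Compound 1 stands clearly higher.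

Compound 4 `COc1cc(-c2nn(-c3cccc(NC(=O)c4ccc(Cl)c(C(F)(F)F)c4)c3)cc2-c2ccncc2)ccc1Cl` has not yet been measured. Its difference from compound 2 is 4-chloro-3-(trifluoromethyl)phenyl in place of (3,4-dichlorophenyl)amino on a carbonyl carbon. Among the compounds with values here, no measured step makes this exact change, and nothing here tests the loss of the amino part. The closest guide is a 3.3-fold lower number from compound 1 to compound 3 (0.52 log units; beyond the scatter), which replaces a trifluoromethyl-bearing ring with 3,4-dichlorophenyl. Compound 4 moves partly the opposite way, so a higher number is expected in this assay, though a smaller rise than that step, given that one chlorine stays on the new ring. The estimated change is a 1.7-fold higher number from compound 2 to compound 4 (0.23 log units; within the scatter). For compound 4 the expected value is 1800 nM, with an estimated range from 600 nM to 5500 nM.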

Compound 4, concentration for 50% growth inhibition: 2190 nM
For compound 4 the middle estimate is 1.2-fold (0.09 log units) below the measured one, and the stated range covers the measured number.
By their numbers in this assay, from the lowest: compounds 2, 3, 4 and 1 (each within the scatter of the next, the first and the last beyond it).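

Within the data shown here, the new step is the first to change what sits on the carbonyl carbon itself: in this assay there is a 2.1-fold higher number from compound 2 to compound 4 (0.32 log units; beyond the scatter) when 4-chloro-3-(trifluoromethyl)phenyl takes the place of (3,4-dichlorophenyl)amino. Growth inhibition therefore weakens only modestly, and activity survives without the amino nitrogen and its hydrogen-bond donor. Nothing measured here explains this rise.

From the compounds shown here alone, the change removes the amino nitrogen and alters the ring in one move, so the share of each remains open, and a 3,4-dichlorophenyl ring placed directly on the carbonyl carbon, or the amino form carrying 4-chloro-3-(trifluoromethyl)phenyl, would separate them. Also open, going by these compounds, is how an amine or a carboxylic acid on that ring would behave.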